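Chloro for methyl on the 4-methylphenyl group

The source may hold more compounds than are shown below. What is called first, only, known or untested is meant among the compounds shown, and "the series" means these compounds.

Three compounds of the series have been run in a functional assay on CHO cells for inhibition of transient receptor potential cation channel subfamily V member 1 (Homo sapiens); a higher number here means a weaker inhibitor, a lower number a stronger inhibitor. Compound 1 `CC(C)(C)c1ccc(CCC(=O)Nc2ccc3c(c2)OCCO3)cc1` gives 660 nM. Compound 3 `Cc1ccc(/C=C/C(=O)Nc2ccc3c(c2)OCCO3)cc1` gives 1100 nM, the higher of the two numbers, and its gap to compound 1 lies within the scatter, so the two read as equivalent. Compound 2 `CC(C)(C)c1ccc(/C=C(/C(=O)Nc2ccc3c(c2)OCCO3)c2ccccc2)cc1` reaches only a limit of the assay, > 4000 nM, which is the limit of > 4000 nM in this assay, at which 1 of the 3 values shown sits.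

Compound 4 `O=C(/C=C/c1ccc(Cl)cc1)Nc1ccc2c(c1)OCCO2` has not yet been measured. It differs from compound 3 by chloro in place of methyl on an aromatic carbon; one bond further out the change reads 4-methylphenyl to 4-chlorophenyl. For the measured compounds named here, no measured pair carries this change, so there is nothing to size it against, and the expectation is a step within the scatter, with no clear direction. Compound 4 is therefore expected at 900 nM, within 400 nM to 2200 nM. The expected step is a 1.2-fold lower number from compound 3 to compound 4 (0.09 log units; within the scatter), no more than the scatter.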

Compound 4, half-maximal inhibitory concentration: 320 nM
Compound 4: the middle estimate sits 2.8-fold (0.45 log units) above what was measured, outside the stated range (below it).
By their numbers in this assay, from the lowest: compound 4; then compounds 1 and 3 (each within the scatter of the next). At a limit, above all of these: compound 2.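

In this assay, for the compounds shown here, the aromatic carbon para to a large group proves sensitive to the group it carries: chloro in place of methyl gives a 3.4-fold lower number from compound 3 to compound 4 (0.54 log units; beyond the scatter) and is the first single-place change that can be sized. Methyl and chloro match in their counts of heavy atoms, hydrogen-bond donors and hydrogen-bond acceptors, so these counts do not separate compound 3 from compound 4. Nothing measured on these compounds bears on why the number moves with this change.

From the compounds shown here alone, whether bromo, methoxy, an amine or a carboxylic acid at this position would give a lower or higher number remains open. Also open, going by these compounds, is whether chloro in place of methyl gives a similar step on a different core or linker.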